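A few compounds are considered here, and "the series" means these few. Any claim that something is new, unique, unknown or untested is made for them only; others in the source may bear on it.

Measured so far:
compound 1 `COc1ccc(C(=O)c2cc(OC)c(OC)c(OC)c2)cc1NC(=O)/C=C/c1cc(OC)c(OC)c(OC)c1`, 3100 nM
compound 2 `COc1cc(C(=O)c2cc(OC)c(OC)c(OC)c2)cc(NC(=O)/C=C/c2cc(OC)c(OC)c(OC)c2)c1OC`, 3100 nM

In a functional assay on HT-29 cells (Homo sapiens) for cytotoxicity, read by MTT assay, with a stated time of 72 h (a lower number here means a stronger inhibitor, a higher number a weaker inhibitor), compound 2 gives 3100 nM and stands level with compound 1 at the digits shown; the step of no change at the digits printed from compound 1 to compound 2 (within the scatter) lies within the scatter. Compound 3 `COc1ccc(/C=C/C(=O)Nc2cc(C(=O)c3cc(OC)c(OC)c(OC)c3)cc(OC)c2OC)cc1` differs from compound 2 by 4-methoxyphenyl in place of 3,4,5-trimethoxyphenyl on a double-bonded chain carbon bound to a double-bonded chain carbon. Within the data shown here, no measured step concerns the group on the double-bonded chain carbon; the only step in the set, no change at the digits printed from compound 1 to compound 2 (within the scatter), concerns a methoxy on an aromatic carbon of the core and so does not bear on this change. With nothing further to go on, the expectation for compound 3 is a step of a 1.5-fold higher number from compound 2 to compound 3 (0.16 log units; within the scatter) in this assay, of uncertain direction and possibly not beyond the scatter, carrying a wide range. Compound 3 is therefore expected to give 4500 nM, with a range from 1500 nM to 14000 nM.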

Compound 3, half-maximal inhibitory concentration: 3800 nM
The estimate for compound 3 lay 1.2-fold (0.07 log units) above the measured number; low and high end bracket the measured number.
By their numbers in this assay, from the lowest: compounds 1, 2 and 3 (each within the scatter of the next).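

In this assay, among these compounds, 4-methoxyphenyl in place of 3,4,5-trimethoxyphenyl on a double-bonded chain carbon bound to a double-bonded chain carbon gives a 1.2-fold higher number from compound 2 to compound 3 (0.09 log units; within the scatter) and so gives the first reading at this position, since the earlier step concerned only a methoxy on an aromatic carbon of the core. A group of 8 heavy atoms with 1 hydrogen-bond acceptor thus stands in for one of 12 heavy atoms with 3 hydrogen-bond acceptors, and the assay does not separate the two, so the full trimethoxy pattern is not required to hold this level. No measured evidence accounts for this result.

Open, from the compounds shown here alone, is whether this position responds to anything other than a methoxy-substituted phenyl, for example an unsubstituted phenyl, a pyridine ring or an aniline amine. Also open, going by these compounds, is whether any change on this series moves the number beyond the scatter.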